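The compounds below may be only part of what the source reports. "The series", "measured", "known", "first", "only" and "open" are said of these compounds alone.

Compound 1 `Cc1ccc(C)n1-c1cccc(-c2nnn[nH]2)c1`, compound 2 `Cc1cc(/C=C2\SC(=S)N(c3ccccc3)C2=O)c(C)n1-c1cccc(-c2nnn[nH]2)c1` and compound 3 `Cc1cc(/C=C2\SC(=S)N(c3cccc([N+](=O)[O-])c3)C2=O)c(C)n1-c1cccc(-c2nnn[nH]2)c1` share one core. In an ADME assay on MT2 cells (Homo sapiens) for cytotoxicity, read by XTT assay, with a stated time of 4 days (on this read-out higher numbers stand for lower toxicity in this test and lower numbers for higher toxicity in this test), compound 1 gives 250000 nM, compound 2 gives 61000 nM and compound 3 gives 77000 nM. Among the compounds with values here, compound 3 thus stands second highest of the three numbers in this assay: its nearest neighbour is compound 2, and the only step measured so far, a 1.3-fold higher number from compound 2 to compound 3 (0.10 log units; within the scatter), lies within the scatter, while compound 1 gives a number beyond the scatter above it.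

Compound 4 `Cc1cc(/C=C2\SC(=S)N(c3ccc(Br)cc3)C2=O)c(C)n1-c1cccc(-c2nnn[nH]2)c1` is not yet measured in this assay. It differs from compound 3 in one place: 4-bromophenyl in place of 3-nitrophenyl on an amide-type nitrogen in a ring. Within the data shown here, the one step that bears on this position, a 1.3-fold higher number from compound 2 to compound 3 (0.10 log units; within the scatter), shows that exchanging groups on this ring moved the number little. Among the measured compounds shown here, no step covering a bromine at this position exists, so the expectation rests on that single comparison. Compound 4 is therefore expected to give a number close to compound 3, with a 1.2-fold lower number from compound 3 to compound 4 (0.07 log units; within the scatter), and its estimate in this assay is 65000 nM with a range from 30000 nM to 140000 nM.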

Compound 4, half-maximal cytotoxic concentration: 46800 nM
Compound 4: middle estimate off by 1.4-fold (0.14 log units), on the high side; the measured number falls inside the stated range.
By their numbers in this assay, from the lowest: compounds 4, 2 and 3 (each within the scatter of the next); then compound 1.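

With the new compound, the aryl group on the amide-type nitrogen in the ring has been varied in three forms in this assay, and none of the exchanges leaves the scatter: a 1.6-fold lower number from compound 3 to compound 4 (0.22 log units; within the scatter) and a 1.3-fold lower number from compound 2 to compound 4 (0.12 log units; within the scatter). Earlier, only the addition of a nitro group could be judged at this position; the bromo addition now gives a second case, and 4-bromophenyl, 3-nitrophenyl and the unsubstituted phenyl ring of compound 2 cannot be told apart by this read-out. Nothing at hand accounts for this result.

The compounds shown leave open whether an amine or a carboxylic acid on this aromatic ring would move the number beyond the scatter. They also leave open what a longer alkyl chain on that nitrogen, in place of the aromatic ring, would give.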